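A few compounds are considered here, and "the series" means these few. Any claim that something is new, unique, unknown or untested is made for them only; others in the source may bear on it.

Measured compounds:
compound 1 `COc1cc(NC(C)CCCNC(=O)Nc2ccc(Br)cc2)c2ncccc2c1` — 18000 nM
compound 2 `COc1cc(NC(C)CCCNC(=O)Nc2ccc(C(F)(F)F)cc2)c2ncccc2c1` — 7400 nM
compound 3 `COc1cc(NC(C)CCCNC(=O)NNC(=O)Nc2cccc(Cl)c2)c2ncccc2c1` — 27000 nM

All three share the same core and were read in a functional assay on L1210 cells (Mus musculus) for inhibition, read by MTT assay, with a stated time of 72 h; on this read-out lower numbers stand for stronger inhibition and higher numbers for weaker inhibition. Compound 1 stands second highest of the three numbers. Its nearest neighbour is compound 3: a 1.5-fold higher number from compound 1 to compound 3 (0.18 log units; within the scatter), a step that stays within the scatter. The furthest is compound 2: a 2.4-fold lower number from compound 1 to compound 2 (0.39 log units; beyond the scatter), a modest step beyond the scatter.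

The unmeasured compound 4 `COc1cc(NC(C)CCCNC(=O)NNC(=O)Nc2ccc(O)cc2)c2ncccc2c1` differs from compound 1 in one place, (((4-hydroxyphenyl)carbamoyl)amino in place of 4-bromophenyl on an amide-type nitrogen). For the measured compounds named here, the step that bears on it most directly is the one from compound 1 to compound 3, where the same kind of exchange, with ((3-chlorophenyl)carbamoyl)amino entering, gave a 1.5-fold higher number from compound 1 to compound 3 (0.18 log units; within the scatter). The step from compound 2 to compound 3 points the same way and is larger, a 3.6-fold higher number from compound 2 to compound 3 (0.56 log units; beyond the scatter). Going by the values given here, no compound carries a hydroxy on the outer ring, so the effect of that part of the change is unknown. For this assay the expectation is therefore a small step from compound 1 to compound 4, if any beyond the scatter, toward a higher number: a 1.4-fold higher number from compound 1 to compound 4 (0.14 log units; within the scatter). The estimate for compound 4 is 25000 nM, with a range from 10000 nM to 60000 nM.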

Compound 4, half-maximal inhibitory concentration: 95000 nM
Beside the measured number, compound 4's estimate is 3.8-fold (0.58 log units) below it; measured number above the stated range.
By their numbers in this assay, from the lowest: compound 2; then compounds 1 and 3 (each within the scatter of the next); then compound 4.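

In this assay, the exchange at this amide-type nitrogen is no longer neutral: ((3-chlorophenyl)carbamoyl)amino in place of 4-bromophenyl stayed within the scatter, whereas ((4-hydroxyphenyl)carbamoyl)amino gives a 5.3-fold higher number from compound 1 to compound 4 (0.72 log units; beyond the scatter) and, in place of 4-(trifluoromethyl)phenyl, a 13-fold higher number from compound 2 to compound 4 (1.11 log units; beyond the scatter). The outer ring therefore counts in its own right: with the rest of the entering group held constant, 4-hydroxyphenyl in place of 3-chlorophenyl gives a 3.5-fold higher number from compound 3 to compound 4 (0.55 log units; beyond the scatter), so the carbamoylamino extension alone does not account for the high number of compound 4. Nothing available on these compounds speaks to what lies behind this step.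

Compounds 3 and 4 differ in both the substituent and its ring position, so the shift cannot yet be assigned to the hydroxy group or to where it sits; a 4-chlorophenyl or a 3-hydroxyphenyl on the same extended group would separate the two. A 4-methoxyphenyl or 4-aminophenyl there would show whether the high number is specific to the hydroxy group, and 4-hydroxyphenyl directly on the amide-type nitrogen would show whether it depends on the extension.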